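Replacing Pyridin-3-yl With 4-Hydroxyphenyl on a Shared Core

A few compounds are considered here, and "the series" means these few. Any claim that something is new, unique, unknown or untested is made for them only; others in the source may bear on it.

In a functional assay on MIA PaCa-2 cells (Homo sapiens) for antiproliferative activity, read by MTT assay, with a stated time of 24 h (on this read-out higher numbers stand for weaker inhibition and lower numbers for stronger inhibition), compound 3 `COc1ccc(-c2noc(-c3cccnc3)n2)cc1OC1CCCC1` reads > 1000000 nM, which is a limit of the assay and not a number. The two related compounds do give numbers: compound 1 `COc1ccc(-c2noc(C3CCCN3)n2)cc1OC1CCCC1` reads 19500 nM, and compound 2 `COc1ccc(-c2noc(-c3ccc(F)cc3)n2)cc1OC1CCCC1` reads 6090 nM.

Compound 4 `COc1ccc(-c2noc(-c3ccc(O)cc3)n2)cc1OC1CCCC1` keeps the shared core and changes one group: 4-hydroxyphenyl in place of pyridin-3-yl on an aromatic carbon. The entering group brings one six-membered aromatic ring of carbon only.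

The most relevant measured step is an at least 160-fold higher number from compound 2 to compound 3 (2.21 log units; beyond the scatter), a large one, which placed pyridin-3-yl where 4-fluorophenyl had been. The step of an at least 51-fold higher number from compound 1 to compound 3 (1.70 log units; beyond the scatter) is also large and was made by the same group entering. By contrast, a 3.2-fold lower number from compound 1 to compound 2 (0.51 log units; beyond the scatter) is only modest. Compound 4 resembles compound 2 6090 nM in carrying a ring of carbon only, so a large step to a lower number is expected in this assay. The hydroxyl group has not been tested in this series, so the expectation stays broad. For compound 4, the estimated value is 12000 nM, with an expected range from 3000 nM to 60000 nM. This estimate corresponds to an expected at least 83-fold lower number from compound 3 to compound 4 (1.92 log units; beyond the scatter).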

Compound 4, half-maximal inhibitory concentration: 480 nM
Compound 4: middle estimate off by 25-fold (1.40 log units), on the high side; measured number below the stated range.
By their numbers in this assay, from the lowest: compound 4; then compound 2; then compound 1. At a limit, above all of these: compound 3.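

Going by these compounds alone, the earlier compounds showed only that the group on this aromatic carbon of the five-membered ring matters; compound 4 shows that a single change on the outer ring also counts. In this assay, there is a 13-fold lower number from compound 2 to compound 4 (1.10 log units; beyond the scatter), with hydroxy in place of fluoro and the carbon-only ring kept, and there is also a 41-fold lower number from compound 1 to compound 4 (1.61 log units; beyond the scatter), which leaves compound 4 with the lowest number of the series. Against pyridin-3-yl the change gives an at least 2000-fold lower number from compound 3 to compound 4 (3.31 log units; beyond the scatter), so two six-membered aromatic rings at the same place can lie very far apart, and this step is only a bound: compound 3 stands at a limit and has no number of its own: the limit of > 1000000 nM in this assay, at which 1 of the 4 values shown sits.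

The compounds shown leave open whether another group in place of hydroxy on this ring, such as an amine, a methoxy group or a carboxylic acid, would keep the number as low as in compound 4. With no plain phenyl group among them, they also cannot say how much of the step from fluoro to hydroxy comes from gaining the hydroxy group and how much from losing the fluoro group.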